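Swapping the pyridyl ring of compound 1 for a substituted phenyl

This account rests on a few compounds, and the source may have more. Where it says the series, first, only, none or still open, it means among the compounds named here.

Compound 1, `CC[C@@H](Nc1c(C#N)c(-c2ccc(-c3ncccc3C)cc2)nc2cnccc12)C(N)=O`, is the least lipophilic of the three measured compounds in a physicochemical assay for lipophilicity, read by HPLC, at pH 7.5 (on this read-out higher numbers stand for higher lipophilicity and lower numbers for lower lipophilicity), where compound 1 gives 2. Compound 2, `CCOc1ccccc1-c1ccc(-c2nc3cnccc3c(N)c2C#N)cc1`, gives 3 in this assay, and compound 3, `CCOc1ccccc1-c1ccc(-c2nc3cnccc3c(NC(CC)CNS(=O)(=O)C3CC3)c2C#N)cc1`, gives 3.6. Going by the values given here, the only single-point step among them is a number 0.60 log units higher from compound 2 to compound 3 (beyond the scatter), a change on a nitrogen on an aromatic ring that does not touch the biaryl end of the molecule.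

The new compound 4, `CC[C@@H](Nc1c(C#N)c(-c2ccc(-c3cccc(Cl)c3OC)cc2)nc2cnccc12)C(N)=O`, differs from compound 1 in one place: 3-chloro-2-methoxyphenyl in place of 3-methylpyridin-2-yl on an aromatic carbon. Among the compounds with values here, no measured step addresses this kind of change; the step from compound 2 to compound 3 concerns a different part of the shared core, and compound 1 and compound 2 differ in more than one place, so their values give only a loose orientation. With a pyridin-2-yl leaving and a phenyl carrying chlorine and methoxy entering, compound 4 is expected to read higher than compound 1 in this assay, by a number 1.00 log units higher from compound 1 to compound 4 (beyond the scatter) as estimated here. On that basis compound 4 is estimated at 3, with a range from 2.3 to 3.7.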

Compound 4, distribution coefficient: 3.1
Estimate against measurement, compound 4: 0.10 log units below, within the range that was stated.
By their numbers in this assay, from the lowest: compound 1; then compounds 2 and 4 (each within the scatter of the next); then compound 3.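

In this assay, 3-chloro-2-methoxyphenyl in place of 3-methylpyridin-2-yl gives a number 1.10 log units higher from compound 1 to compound 4 (beyond the scatter) as a large step, and it is the first step shown at this position, on an aromatic carbon para to a large group. Going by these compounds alone, the only earlier step, a number 0.60 log units higher from compound 2 to compound 3 (beyond the scatter), lies elsewhere, on a nitrogen on an aromatic ring, and it says nothing about this position. The step at this position comes with the entering and leaving groups matched in their counts of hydrogen-bond donors and acceptors and in net charge, while the ring changes from one with a hetero atom to one of carbon only and the group gains chlorine and methoxy; no evidence at hand accounts for the step.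

The compounds shown leave open how the step divides among the loss of the ring nitrogen, the chlorine and the methoxy, which a 3-chlorophenyl or a 2-methoxyphenyl at this position would begin to separate. They also leave open how this position would read with an amine or a carboxylic acid on the ring, and whether the step holds with a different group on the aromatic nitrogen.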